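A few compounds are considered here, and "the series" means these few. Any claim that something is new, unique, unknown or untested is made for them only; others in the source may bear on it.

Compound 1 `CC(C)CC1OCCC(Cl)=C1[Si](C)(C)C`: in a functional assay on SW1573 cells (Homo sapiens) for antiproliferative activity (a higher number here means a weaker inhibitor of growth, a lower number a stronger inhibitor of growth), compound 1 gives 28000 nM.
Compound 2 `C[C@H]1CC(Cl)=C([Si](C)(C)C)[C@@H](C2CCCCC2)O1`: in this assay compound 2 gives 31000 nM.
Compound 3 `CC[C@H]1CC(Cl)=C([Si](C)(C)C)[C@@H](C2CCCCC2)O1`: in this assay compound 3 gives 49000 nM.

Compound 2 has the second highest of these three numbers, yet its gap to compound 1 and its gap to compound 3 both lie within the usual scatter of this kind of measurement, so the three compounds cannot be told apart on the numbers shown.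

Compound 4 `C[Si](C)(C)C1=C(Cl)C[C@H](C2CCCCC2)O[C@@H]1C1CCCCC1` differs from compound 2 in one place: cyclohexyl in place of methyl on a saturated ring carbon. Among the measured compounds shown here, only one measured step bears on this change. Going from compound 2 to compound 3 swapped hydrogen for methyl on a saturated chain carbon bound to a saturated ring carbon and gave a 1.6-fold higher number from compound 2 to compound 3 (0.20 log units; within the scatter), a step within the scatter. For the measured compounds named here, that step is only a loose guide here, as the present change swaps a methyl for a much bulkier cyclohexyl and sits on the ring itself, at a place where no measured compound has varied. With a single related step that stayed within the scatter, the expected step for compound 4 is a 1.1-fold higher number from compound 2 to compound 4 (0.05 log units; within the scatter), with no clear direction. Compound 4 is therefore estimated at 35000 nM in this assay, within a range from 12000 nM to 100000 nM.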

Compound 4, concentration for total growth inhibition: 48000 nM
For compound 4 the middle estimate is 1.4-fold (0.14 log units) below the measured one; low and high end bracket the measured number.
By their numbers in this assay, from the lowest: compounds 1, 2, 4 and 3 (each within the scatter of the next).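

Compound 4 is the first of those shown to put a ring, rather than a short chain, on the saturated ring carbon next to the ring oxygen, a change from 1 heavy atom in the methyl to 6 heavy atoms in the cyclohexyl. Even so, this assay gives a 1.5-fold higher number from compound 2 to compound 4 (0.19 log units; within the scatter), and the swap of ethyl for cyclohexyl at the same carbon gives a 1.0-fold lower number from compound 3 to compound 4 (0.01 log units; within the scatter), so among compounds 2, 3 and 4 methyl, ethyl and cyclohexyl at this position cannot be told apart. No measurement at hand offers an explanation for why this large difference in group size leaves the numbers so close.

The compounds shown leave open whether a group of another kind on this carbon, such as an amine, a carboxylic acid or a phenyl ring, would move the number beyond the scatter. They also leave open whether replacing the chloro group with a bromo group or a nitrile would do so.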